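A few compounds are considered here, and "the series" means these few. Any claim that something is new, unique, unknown or untested is made for them only; others in the source may bear on it.

Compound 1 `CCCCO/N=C/c1c(N)ncnc1Oc1ccc2[nH]c(C)cc2c1F` sits at the high end of the two numbers in a functional assay on HeLa cells (Homo sapiens) for antiproliferative activity (on this read-out higher numbers stand for weaker inhibition and lower numbers for stronger inhibition), where compound 1 gives 607 nM and compound 2 `C=CCO/N=C/c1c(N)ncnc1Oc1ccc2[nH]c(C)cc2c1F` gives 42 nM. Going by the values given here, the one recorded step on that chain, a 14-fold lower number from compound 1 to compound 2 (1.16 log units; beyond the scatter), was large. Compound 3 `Cc1cc2c(F)c(Oc3ncnc(N)c3/C=N/OCCO)ccc2[nH]1` differs from compound 1 by hydroxy in place of ethyl on a saturated chain carbon, two bonds along the chain from an oxygen on an unsaturated carbon. That step touches the same chain as the step from compound 1 to compound 2 but with a different group entering, so a lower number is expected, though smaller than a 14-fold lower number from compound 1 to compound 2 (1.16 log units; beyond the scatter). Compound 3 is estimated at 200 nM, within 60 nM to 700 nM, a step of a 3.0-fold lower number from compound 1 to compound 3 (0.48 log units; beyond the scatter).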

Compound 3, half-maximal inhibitory concentration: 406 nM
Compound 3: middle estimate off by 2.0-fold (0.31 log units), on the low side; the range from low to high includes it.
By their numbers in this assay, from the lowest: compound 2; then compounds 3 and 1 (each within the scatter of the next).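

In this assay, hydroxy in place of ethyl gives a 1.5-fold lower number from compound 1 to compound 3 (0.17 log units; within the scatter), so the 2-hydroxyethoxy and butoxy chains cannot be told apart here. The same compound stands well away from the allyl-type chain of compound 2, with a 9.7-fold higher number from compound 2 to compound 3 (0.99 log units; beyond the scatter), so among these three only the vinyl-bearing chain gives the clearly lower number. Nothing measured here explains this difference. The compounds shown leave open whether an amine or a methoxy group in place of the hydroxy would read like compound 3, and whether an ethynyl group in place of the vinyl would keep the number of compound 2.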